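The compounds below may be only part of what the source reports. "The series", "measured", "known", "first", "only" and "open" are said of these compounds alone.

The measured compounds:

Compound 1 `N#Cc1ccccc1CN1C(=O)N(Cc2cccc(Cl)c2)S(=O)(=O)n2cccc21` gives > 293000 nM in an ADME assay on MT4 cells (Homo sapiens) for cytotoxicity, read by MTT assay, with a stated time of 5 days (a lower number here means that less compound is tolerated, a higher number that more compound is tolerated), which is a limit of the assay and not a number.
Compound 2 `O=C1N(Cc2ccccc2Cl)c2cccn2S(=O)(=O)N1Cc1cccc(Br)c1` gives > 260000 nM in this assay, which is again a limit.
Compound 3 `N#Cc1ccccc1CN1C(=O)N(Cc2ccccc2)S(=O)(=O)n2cccc21` gives > 318000 nM in this assay, which is again a limit.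

From compound 3 to compound 1 the change is chloro in place of hydrogen on an aromatic carbon. The step that the two limits leave unreadable from compound 3 to compound 1 cannot be read, since compound 3 sits at the limit of > 318000 nM in this assay, at which 1 of the 3 values shown sits, and compound 1 sits at the limit of > 293000 nM in this assay, at which 1 of the 3 values shown sits.

Compound 4 `O=C1N(Cc2ccc(Cl)cc2Cl)c2cccn2S(=O)(=O)N1Cc1cccc(Br)c1` has not yet been measured in this assay. Going by the values given here, it differs from compound 2 by chloro in place of hydrogen on an aromatic carbon, the same kind of change as the one from compound 3 to compound 1, but not the same: in compound 1 the entering chloro sits meta to a large group, whereas in compound 4 it sits meta to a chloro group and para to a large group. How the core of compound 2 differs from the core of compound 3 is not broken down here.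

Compound 2 sits at the limit of > 260000 nM in this assay, at which 1 of the 3 values shown sits, and the step from compound 3 to compound 1 is unreadable, so the expected step that the limit leaves unreadable from compound 2 to compound 4 rests on no measured number and is taken as small. Compound 4 is therefore expected to give about 280000 nM, between 90000 nM and 600000 nM, most likely again reported only as a limit.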

Compound 4, half-maximal cytotoxic concentration: > 243000 nM
Compound 4 was reported as a limit; the forecaster's own chance of this, stated with the estimate: 80%; the middle value is on the limit's open side.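

Compound 2 and compound 4 both stand only as limits in this assay, not as numbers, and the step from compound 2 to compound 4 cannot be read. All four compounds shown are reported as limits, which leaves open where the half-maximal cytotoxic concentration of any of them lies and whether chloro in place of hydrogen on an aromatic carbon changes it at all.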